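The compounds below may be only part of what the source reports. "The series", "measured", "known", "first", "only" and "open" are said of these compounds alone.

Measured so far:
- compound 1, `O=C(CCCCCCCC(=O)c1ccccc1)NO`: 65 nM
- compound 2, `COc1ccccc1C(=O)CCCCCCCC(=O)NO`: 95 nM
- compound 3, `COc1ccc(CS(=O)(=O)Nc2ccc(/C=C\C(=O)NO)cc2)cc1`: 60 nM

All three numbers come from an assay on isolated protein for inhibition of histone deacetylase 8 (Homo sapiens); on this read-out lower numbers stand for stronger inhibition and higher numbers for weaker inhibition. The step of a 1.5-fold higher number from compound 1 to compound 2 (0.16 log units; within the scatter) is methoxy in place of hydrogen on an aromatic carbon, placed ortho to a large group. Compound 4, `COc1ccc(CS(=O)(=O)Nc2ccc(/C=C\C(=O)NO)cc2)cc1OC`, is not yet measured; it arises from compound 3 by methoxy in place of hydrogen on an aromatic carbon, here placed ortho to a methoxy group (2 heavy atoms) and meta to a large group. The two changes are of the same kind, but not the same, since the surroundings of the place differ. The difference between the core of compound 1 and the core of compound 3 is not broken down here. Compound 3 and compound 1 give numbers that lie within the scatter of each other, as do compound 3 and compound 2.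

Going by the values given here, with only one earlier example of this kind of change, the expectation for compound 4 rests on the step of a 1.5-fold higher number from compound 1 to compound 2 (0.16 log units; within the scatter) transferred to the different core, so a step of about a 1.3-fold higher number from compound 3 to compound 4 (0.12 log units; within the scatter) is expected in this assay. Compound 4 is estimated at 80 nM, with a range of 35 nM to 180 nM.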

Compound 4, half-maximal inhibitory concentration: 90 nM
Beside the measured number, compound 4's estimate is 1.1-fold (0.05 log units) below it; low and high end bracket the measured number.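

In this assay, methoxy in place of hydrogen on an aromatic carbon gives a 1.5-fold higher number from compound 3 to compound 4 (0.18 log units; within the scatter), and this step matches the earlier one on the other core: the same change on two cores in this assay, a 1.5-fold higher number (0.16 log units; within the scatter) from compound 1 to compound 2 and a 1.5-fold higher number (0.18 log units; within the scatter) from compound 3 to compound 4, 1.0-fold (0.01 log units) apart, within the scatter of two such steps

On these two cores, then, the change carries over with no detectable difference in step size, but both steps lie within the scatter, so neither pair shows that the methoxy itself has any effect on the read-out, and agreement between two such small steps is weak support for transfer. The surroundings also differ, since in compound 4 the methoxy sits ortho to a methoxy group and meta to a large group, and a single pair on each core cannot separate the influence of the core from that of the place.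

As far as these compounds go, whether a hydroxyl, an amine or a carboxylic acid at the same place would give a step beyond the scatter stays open. Also open, from the compounds shown here alone, is whether the same agreement would hold on a third core.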